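This account rests on a few compounds, and the source may have more. Where it says the series, first, only, none or still open, it means among the compounds named here.

Measured so far in a toxicity assay on J774.A1 cells (Mus musculus) for cytotoxicity, read by SYBR Green assay, with a stated time of 1 h; on this read-out lower numbers stand for an effect already at smaller amounts and higher numbers for an effect only at larger amounts of compound
- compound 1 `CN(C)c1ccc2cc(-c3cccc(Cl)c3)c(N)nc2c1` gives 13000 nM
- compound 2 `CN(C)c1ccc2cc(-c3cc(Cl)cc(Cl)c3)c(N)nc2c1` gives 3700 nM
- compound 3 `CN(C)c1ccc2cc(-c3nc4cc(C(C)(C)C)ccc4o3)c(N)nc2c1` gives 10000 nM

Compound 2 has the lowest number of these three, so it shows its effect at the smallest amount. The numbers of compound 1 and compound 3 both lie higher.

Compound 4 `Nc1nc2cc(N3CCCCC3)ccc2cc1-c1cc(Cl)cc(Cl)c1` is compound 2 with a single change: piperidin-1-yl in place of dimethylamino on an aromatic carbon. The new group sits where the old one did, and the rest of the molecule stays the same.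

Within the data shown here, only one measured step is available (a 3.5-fold lower number from compound 1 to compound 2 (0.55 log units; beyond the scatter)), and it brings chloro in place of hydrogen on an aromatic carbon. That is a modest step at a different place in the molecule. It therefore offers only a rough gauge of how far one small change has moved the number here. Among the measured compounds shown here, no measured pair shows what happens when dimethylamino is replaced, so the data give no firm direction for this change.

The expected result is a 1.2-fold lower number from compound 2 to compound 4 (0.09 log units; within the scatter) in this assay, which means no clear shift is expected. The estimate for compound 4 is 3000 nM (expected range 1200 nM to 8000 nM).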

Compound 4, half-maximal effective concentration: 6800 nM
Estimate against measurement, compound 4: 2.3-fold (0.36 log units) below; measured number inside the range.
By their numbers in this assay, from the lowest: compounds 2, 4, 3 and 1 (each within the scatter of the next, the first and the last beyond it).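

In this assay the only step shown at the aromatic carbon that carries dimethylamino is the exchange for piperidin-1-yl, a 1.8-fold higher number from compound 2 to compound 4 (0.26 log units; within the scatter), and a step of this size cannot be told apart from the ordinary variation between repeated measurements. The earlier compounds shown here said nothing about this place, but this pair shows that a group of 6 heavy atoms, closed into a six-membered non-aromatic ring, can stand where a group of 3 heavy atoms without a ring stood, with no clear shift in the number. No measurement shown here bears on why the two compounds read alike.

This single pair leaves open whether other groups at this place, such as morpholin-4-yl with its ring oxygen or a plain amino group, would also stay within the scatter of compound 2. It also leaves open whether the same exchange would behave alike in compound 1 or compound 3, which carry a different group on the other side of the shared core.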